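Moving the Fluorine Between Two Inactive Compounds

A few compounds are considered here, and "the series" means these few. Any claim that something is new, unique, unknown or untested is made for them only; others in the source may bear on it.

Compound 2 `Oc1ccc(-c2cc(-c3cccc(F)c3)cc(-c3ccccc3O)n2)cc1` was measured in a functional assay on DU-145 cells (Homo sapiens) for inhibition; a lower number here means a stronger inhibitor, a higher number a weaker inhibitor. Compound 2 gives > 50000 nM in this assay, which is a limit of the assay rather than a number. Compound 1 `Oc1cccc(-c2cc(-c3ccc(F)cc3)cc(-c3ccccc3O)n2)c1` gives > 50000 nM in this assay, again a limit. Both values shown therefore share one position: the limit of > 50000 nM in this assay, at which 2 of the 2 values shown sit. Compound 2 thus stands at the edge of what this assay can report, with no number to compare.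

Compound 3 `Oc1ccc(-c2cc(-c3ccc(F)cc3)cc(-c3ccccc3O)n2)cc1` has not yet been measured. It differs from compound 2 by 4-fluorophenyl in place of 3-fluorophenyl on an aromatic carbon; in words, 4-fluorophenyl in place of 3-fluorophenyl on an aromatic carbon. For the measured compounds named here, no step between measured compounds is available, so the size of this change cannot be read from the data. The author expects no step beyond the scatter, because compound 2 gives > 50000 nM and compound 1, carrying the 4-fluorophenyl already, gives > 50000 nM. Compound 3 is therefore estimated at 60000 nM, with a range from 20000 nM to 200000 nM, and the expected step is a step that the limit leaves unreadable from compound 2 to compound 3; most likely the assay will again report only a limit.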

Compound 3, half-maximal inhibitory concentration: > 50000 nM
Compound 3 was reported as a limit; the forecaster's own chance of this, stated with the estimate: 85%; the middle value lies beyond the limit too.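

The steps from compound 1 and from compound 2 to compound 3 cannot be read in this assay, where all three compounds share one position: the limit of > 50000 nM in this assay, at which 3 of the 3 values shown sit.

The compounds shown leave open whether moving the fluorine or the hydroxyl group changes inhibition at all, and which compound on this core would give a readable number.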